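Fluoro to trifluoromethoxy in compound 3

This account rests on a few compounds, and the source may have more. Where it says the series, first, only, none or still open, it means among the compounds named here.

Compound 1 `O=C(/C=C/c1ccc(F)cc1)c1ccccc1`: > 10000 nM (a limit)
Compound 2 `O=C(/C=C/c1ccc(F)cc1)c1cccc(O)c1`: > 10000 nM (a limit)
Compound 3 `O=C(/C=C/c1ccc(OC(F)(F)F)cc1)c1cccc(O)c1`: not yet measured

In a functional assay on RAW264.7 cells (Mus musculus) for inhibition, read by fluorescence, with stated times of 1 h, 24 h and 30 min (a higher number here means a weaker inhibitor, a lower number a stronger inhibitor), compound 2 stands at > 10000 nM, which is a limit and not a number. Both measured compounds share one ceiling: the limit of > 10000 nM in this assay, at which 2 of the 2 values shown sit. Compound 3 carries a single change, (trifluoromethoxy in place of fluoro on an aromatic carbon). Among the measured compounds shown here, the only measured step is a step that the two limits leave unreadable from compound 1 to compound 2, and it concerns hydroxy in place of hydrogen, a different change, so it offers no size to carry over. No direction is indicated, and no step beyond the scatter is expected in this assay. The estimated value for compound 3 is 10000 nM, with an expected range of 3000 nM to 30000 nM. This expectation amounts to a number no higher from compound 2 to compound 3 (the limit leaves the size open).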

Compound 3, half-maximal inhibitory concentration: > 10000 nM
Compound 3 was reported as a limit; the forecaster's own chance of this, stated with the estimate: 60%; the middle value lies on the limit itself.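

In this assay, among the compounds shown here, compound 2 and compound 3 are both reported only as limits, and no step between them can be read. The compounds shown leave open which change, if any, would give a readable value.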